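Cyclobutyl on the amide nitrogen of compound 2

A few compounds are considered here, and "the series" means these few. Any claim that something is new, unique, unknown or untested is made for them only; others in the source may bear on it.

In a functional assay on OVCAR-8 cells (Homo sapiens) for antiproliferative activity (a higher number here means a weaker inhibitor, a lower number a stronger inhibitor), compound 1 (`CN(C)CC[C@@H]1C[C@@H](c2ccc(Cl)c(Cl)c2)[C@H](NC(=O)c2cc(-c3c(Cl)cnn3C)c(Cl)o2)CN1`) gives 1510 nM and compound 2 (`Cn1ncc(Cl)c1-c1cc(C(=O)N[C@@H]2CN[C@H](CC(=O)NCC(O)CO)C[C@H]2c2ccc(Cl)c(Cl)c2)oc1Cl`) gives 5900 nM. Compound 2 therefore holds the higher of the two numbers and is the weaker inhibitor of the measured pair.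

Compound 3 (`Cn1ncc(Cl)c1-c1cc(C(=O)N[C@@H]2CN[C@H](CC(=O)NC3CCC3)C[C@H]2c2ccc(Cl)c(Cl)c2)oc1Cl`) keeps the shared core of compound 2 and has cyclobutyl in place of 2,3-dihydroxypropyl on an amide-type nitrogen.

Among the compounds with values here, the one measured step that bears on this change is a 3.9-fold higher number from compound 1 to compound 2 (0.59 log units; beyond the scatter), a modest step beyond the scatter in which (2,3-dihydroxypropyl)carbamoyl stands in place of (dimethylamino)methyl, and from it a move of somewhat smaller size towards a lower number is expected in this assay. Within the data shown here, this expectation is weakly grounded, since no measured compound carries cyclobutyl and a single step supports the direction.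

The expected step is a 2.7-fold lower number from compound 2 to compound 3 (0.43 log units; beyond the scatter).

For compound 3 the estimated value is 2200 nM, with an expected range of 800 nM to 5500 nM.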

Compound 3, half-maximal inhibitory concentration: 610 nM
The estimate for compound 3 lay 3.6-fold (0.56 log units) above the measured number, outside the stated range (below it).
By their numbers in this assay, from the lowest: compound 3; then compound 1; then compound 2.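

In this assay, the amide-type nitrogen proves to be a position where the substituent matters considerably: cyclobutyl in place of 2,3-dihydroxypropyl gives a 9.7-fold lower number from compound 2 to compound 3 (0.99 log units; beyond the scatter) and places compound 3 lowest of the three. The carbamoyl chain does not go with a higher number as such, since cyclobutylcarbamoyl in place of (dimethylamino)methyl gives a 2.5-fold lower number from compound 1 to compound 3 (0.39 log units; beyond the scatter), whereas (2,3-dihydroxypropyl)carbamoyl in that same place gave a 3.9-fold higher number from compound 1 to compound 2 (0.59 log units; beyond the scatter). Nothing measured on these compounds accounts for either the direction or the size of these steps.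

The compounds shown do not separate the contribution of the four-membered ring from the absence of the hydroxyl groups, as cyclobutyl differs from 2,3-dihydroxypropyl in both respects. A straight butyl chain and a hydroxycyclobutyl on the same amide-type nitrogen would pull these two apart, and a primary amine or a carboxylic acid at the end of a longer chain would show how far this position tolerates other end groups.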